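Shifting the chlorine around the benzyl ring of compound 3

A few compounds are considered here, and "the series" means these few. Any claim that something is new, unique, unknown or untested is made for them only; others in the source may bear on it.

Compound 3 `CC1=C(C(=O)Nc2ccc([N+](=O)[O-])cc2)C(c2ccc(Br)cc2)N=C(SCc2ccccc2Cl)N1` gives 9.7% in a functional assay on the whole organism (artery, strain albino) with Rattus norvegicus as the target, with a stated time of 600 min, at a dose of 10 mg/kg by the oral route (a lower number here means less inhibition, a higher number more inhibition at the dose given (going by the name of the read-out)), the smallest of the three numbers recorded, though it lies within the scatter of compound 1 `COc1ccc(C2N=C(SCc3ccccc3)NC(C)=C2C(=O)Nc2ccc(Br)cc2)cc1` at 11.3% and of compound 2 `COc1ccc(C2N=C(SCc3ccccc3Cl)NC(C)=C2C(=O)Nc2ccc(Br)cc2)cc1` at 13.3%. Compound 4 `CC1=C(C(=O)Nc2ccc([N+](=O)[O-])cc2)C(c2ccc(Br)cc2)N=C(SCc2ccc(Cl)cc2)N1` differs from compound 3 in one place: 4-chlorophenyl in place of 2-chlorophenyl on a saturated chain carbon bound to a sulfur. Within the data shown here, the only measured step touching this part of the molecule, a number 2 percentage points higher from compound 1 to compound 2 (within the scatter), shows that adding a chlorine to the benzyl group changed little; no measured step moves a chlorine from one ring position to another. The step expected from compound 3 to compound 4, a number 1.3 percentage points higher from compound 3 to compound 4 (within the scatter), is therefore none beyond the scatter. Compound 4 is estimated at 11%, within a range from 4% to 20%.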

Compound 4, a percentage reported as inhibition, in the whole organism at one dose (the size of the read-out at that dose, not a potency): 34.4%
Compound 4: middle estimate off by 23.4 percentage points, on the low side, outside the stated range (above it).
By their numbers in this assay, from the lowest: compounds 3, 1 and 2 (each within the scatter of the next); then compound 4.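

In this assay the change from 2-chlorophenyl to 4-chlorophenyl gives a number 24.7 percentage points higher from compound 3 to compound 4 (beyond the scatter) and so separates two compounds with the same atoms. Where the chlorine sits on this ring therefore matters here, although adding a chlorine in a number 2 percentage points higher from compound 1 to compound 2 (within the scatter) changed little. Nothing measured here accounts for the difference.

Going by these compounds, whether an amine or a carboxylic acid in place of the chlorine of 4-chlorobenzyl would keep this higher number remains open. So does whether the same chlorine move would act alike on the core of compound 1.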